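Lengthening the acyl chain: from compound 3 to compound 4

The source may hold more compounds than are shown below. What is called first, only, known or untested is meant among the compounds shown, and "the series" means these compounds.

Compound 1 `Cc1cccc(-c2c(N)n[nH]c2C)c1`: > 100000 nM
Compound 2 `CC(=O)n1nc(C)c(-c2ccc(Cl)c(Cl)c2)c1N`: 8400 nM
Compound 3 `CCC(=O)n1nc(C)c(-c2ccc(Cl)c(Cl)c2)c1N`: 27400 nM

Compound 1 gives only a limit in an assay on Sf9 cells for inhibition of mitogen-activated protein kinase kinase kinase 14 (Homo sapiens), read by ADP-Glo, with a stated time of 60 min (a lower number here means a stronger inhibitor, a higher number a weaker inhibitor), namely > 100000 nM; the value the limit of > 100000 nM in this assay, at which 1 of the 3 values shown sits, is a limit of the assay, not a number. Compound 2 gives 8400 nM in this assay. Compound 3 gives 27400 nM in this assay, which is the highest of the two numbers shown; compound 2 is its nearest neighbour, and the single step between measured compounds is a 3.3-fold higher number from compound 2 to compound 3 (0.51 log units; beyond the scatter), a methyl in place of hydrogen on a saturated chain carbon bound to a carbonyl carbon.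

Compound 4 `CCCC(=O)n1nc(C)c(-c2ccc(Cl)c(Cl)c2)c1N` has not yet been measured. It differs from compound 3 by methyl in place of hydrogen on a saturated chain carbon, two bonds along the chain from a carbonyl carbon, that is, the chain on the carbonyl is extended by one more carbon. Within the data shown here, the one measured step that bears on this change is the earlier extension of the same chain, which raised the number beyond the scatter by a modest amount. A further extension is therefore expected to raise the number again, though the size of such a second step is uncertain and could fall within the scatter. Compound 4 is estimated at 50000 nM, within 15000 nM to 150000 nM, which means an expected step of a 1.8-fold higher number from compound 3 to compound 4 (0.26 log units; within the scatter).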

Compound 4, half-maximal inhibitory concentration: > 100000 nM
Compound 4: a limit, no number (the forecaster's own chance of this, stated with the estimate: 25%); at least 2.0-fold (0.30 log units) between middle value and limit.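

In this assay compound 4 gives no number, only a limit of the assay: the limit of > 100000 nM in this assay, at which 2 of the 4 values shown sit.

The methyl added two bonds along the chain from a carbonyl carbon still brings an at least 3.6-fold higher number from compound 3 to compound 4 (0.56 log units; beyond the scatter), so a second extension of the chain moves the result in the same direction as the first, and the step stays beyond the scatter rather than fading into it. Together with a 3.3-fold higher number from compound 2 to compound 3 (0.51 log units; beyond the scatter) and, over the whole extension, an at least 11-fold higher number from compound 2 to compound 4 (1.07 log units; beyond the scatter), the number rises with each carbon added to the chain on the carbonyl across compound 2, compound 3 and compound 4, and none of these three goes against that pattern, although the true size of the last step cannot be read from a limit.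

The compounds shown leave open whether the fall in strength belongs to chain length alone or would also appear with a branched chain such as isopropyl or a small ring such as cyclopropyl on the carbonyl. They also leave open what an amine or a hydroxyl at the end of the propyl chain would do, and whether a formyl group, shorter than any chain here, would give a lower number than compound 2.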